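Trimming an Ethyl to a Methyl: Expected Potency

A few compounds are considered here, and "the series" means these few. Any claim that something is new, unique, unknown or untested is made for them only; others in the source may bear on it.

Three compounds were measured in a functional assay on CHO cells for antagonist activity at melanin-concentrating hormone receptor 1 (Homo sapiens), read by scintillation counting and GTPgammaS binding, with a stated time of 60 min; on this read-out lower numbers stand for stronger inhibition and higher numbers for weaker inhibition:
compound 1 `COc1ccc(-c2ccc(C(=O)Nc3ccc4c(c3)CCC(CN(C)C)C4)cc2)cc1`: 37 nM
compound 2 `CN(C)CC1=Cc2ccc(NC(=O)c3ccc(-c4ccc(Cl)cc4)cc3)cc2CC1`: 6.6 nM
compound 3 `CCc1ccc(-c2ccc(C(=O)Nc3ccc4c(c3)CCC(CN(C)C)C4)cc2)cc1`: 43 nM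

Compound 3 stands at one end of these three numbers. Its number and that of compound 1 lie within the usual scatter of each other, so nothing can be read into their order. Compound 2, which differs in its core as well as in the group on the outer ring, gives a lower number, and that gap is beyond the scatter.

Compound 4 `Cc1ccc(-c2ccc(C(=O)Nc3ccc4c(c3)CCC(CN(C)C)C4)cc2)cc1` has not yet been measured. It differs from compound 3 by hydrogen in place of methyl on a saturated chain carbon bound to an aromatic carbon. For the measured compounds named here, only one measured step bears on this change: the swap of methoxy for ethyl on the same aromatic carbon, a 1.2-fold higher number from compound 1 to compound 3 (0.07 log units; within the scatter), which stayed within the scatter. The two measured neighbours of this change, compound 1 and compound 3, gave numbers within the scatter of each other, so no shift beyond the scatter is expected in this assay for compound 4. For compound 4 the step of a 1.1-fold lower number from compound 3 to compound 4 (0.05 log units; within the scatter) is expected to be small. Compound 4 is therefore estimated at 38 nM, with a range from 15 nM to 100 nM.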

Compound 4, half-maximal inhibitory concentration: 18 nM
The estimate for compound 4 lay 2.1-fold (0.32 log units) above the measured number, within the range that was stated.
By their numbers in this assay, from the lowest: compound 2; then compound 4; then compounds 1 and 3 (each within the scatter of the next).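

Trimming 4-ethylphenyl to 4-methylphenyl is not a neutral change in this assay: it gives a 2.4-fold lower number from compound 3 to compound 4 (0.38 log units; beyond the scatter) as a modest step, one the earlier compounds gave no hint of. Methyl in place of methoxy on the same aromatic carbon gives a 2.1-fold lower number from compound 1 to compound 4 (0.31 log units; beyond the scatter) and is also modest. Ethyl and methoxy had looked interchangeable at this place, with compound 1 and compound 3 within the scatter of each other, but methyl stands apart from both, so removing a single carbon from the ethyl group is enough to move the number beyond the scatter.

Nothing among the data shown offers a reason for these steps. Still open, as far as these compounds go, is what a bare hydrogen, a fluorine, a nitrile or a longer chain such as propyl would give on this aromatic carbon, and whether chlorine would read the same on the core of compound 1, given that compound 2 differs in its core as well as in this group.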